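Methylating the Carboxylic Acid: From Compound 2 to Compound 3

The source may hold more compounds than are shown below. What is called first, only, known or untested is meant among the compounds shown, and "the series" means these compounds.

This study concerns a small set of triazole-linked phenols tested for their effect on human colon cancer cells. In a functional assay on HCT-116 cells (Homo sapiens) for inhibition, read by MTT assay, with a stated time of 2 days, tested at 10 uM (a lower number here means less inhibition, a higher number more inhibition at the concentration tested (going by the name of the read-out)), compound 1, `COC(=O)c1cc(-n2cc(-c3cc(O)ccc3O)nn2)ccc1O`, gives 15%. Compound 2, `COc1ccc(-c2cn(-c3ccc(O)c(C(=O)O)c3)nn2)cc1`, gives 8% in this assay, and the two numbers lie within the usual scatter of each other, so neither compound can be said to act differently from the other; both show only weak inhibition at the concentration used.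

The step from compound 2 to compound 3, `COC(=O)c1cc(-n2cc(-c3ccc(OC)cc3)nn2)ccc1O`, is a single small change: methyl in place of hydrogen on an oxygen next to a carbonyl group. Cut one bond further out, this reads as carboxy becoming methoxycarbonyl. For the measured compounds named here, no pair of measured compounds differing in one place is available to show what such a change does in this assay, and the two measured numbers themselves sit within the scatter. The step from compound 2 to compound 3 is therefore expected to be small, a number 2 percentage points higher from compound 2 to compound 3 (within the scatter), not clearly beyond the scatter in either direction. Compound 3 is estimated at 10%, in a range from 0% to 25%.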

Compound 3, a percentage reported as inhibition, at one concentration (the size of the read-out at that concentration, not a potency): 6%
The estimate for compound 3 lay 4 percentage points above the measured number; measured number inside the range.
By their numbers in this assay, from the lowest: compounds 3, 2 and 1 (each within the scatter of the next).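

In this assay, for the compounds shown here, the pair of compound 2 and compound 3 gives the first direct reading of carboxy becoming methoxycarbonyl, that is, methyl in place of hydrogen on an oxygen next to a carbonyl group: the result is a number 2 percentage points lower from compound 2 to compound 3 (within the scatter) and so the two compounds cannot be told apart at this position. The other readable step, 4-methoxyphenyl in place of 2,5-dihydroxyphenyl on an aromatic carbon, comes out as a number 9 percentage points lower from compound 1 to compound 3 (within the scatter) and likewise separates nothing, so neither change, taken alone, has a visible effect on inhibition at the concentration tested. Nothing available explains these readings or connects them to a measured property of the compounds.

On these data alone, what stays open is whether a larger group on that same oxygen, such as a longer chain like butyl, or an amide in place of the ester, would move the number clearly beyond the scatter. Going by these compounds alone, it is equally open whether an amine on the aromatic ring in place of methoxy would do so, since every step so far stays within the scatter.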